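The compounds below may be only part of what the source reports. "The series", "measured", "known", "first", "only" and "open" are said of these compounds alone.

Measured in an ADME assay on microsomes from liver (Mus musculus, strain CD1) for metabolic stability, read by HPLC, using NADPH, with a stated time of 30 min; a higher number here means faster removal of the compound, a lower number slower removal:
compound 1 `COc1cccc(NC(=O)c2nnn(Cc3ccncc3)c2N)c1`: 0.7 mL.min-1.g-1
compound 2 `COc1cccc(NC(=O)c2nnn(CC3CCN(C(C)=O)CC3)c2N)c1`: 0.7 mL.min-1.g-1
compound 3 `COc1cccc(NC(=O)c2nnn(Cc3cc(C)on3)c2N)c1`: 2.6 mL.min-1.g-1

Compound 3 stands highest of the three at 2.6 mL.min-1.g-1, and compounds 1 and 2 show the same value. Compound 4 `COc1cccc(NC(=O)c2nnn(Cc3ccc(SC)cc3)c2N)c1`, not yet measured, alters compound 3 in one group: 4-(methylsulfanyl)phenyl in place of 5-methyl-1,2-oxazol-3-yl on a saturated chain carbon bound to an aromatic nitrogen. All three measured steps are changes at this same place. The change seen as no change at the digits printed from compound 1 to compound 2 (within the scatter) stayed within the scatter, while a 3.7-fold higher number from compound 1 to compound 3 (0.57 log units; beyond the scatter) and a 3.7-fold higher number from compound 2 to compound 3 (0.57 log units; beyond the scatter) were modest and beyond it. Among the compounds with values here, those two modest steps bring in the group that compound 4 gives up, but no measured compound carries 4-(methylsulfanyl)phenyl, so the data fix no direction for the new change. In this assay a step no larger than those modest ones is therefore expected, with only a slight upward lean. The estimated step is a 1.5-fold higher number from compound 3 to compound 4 (0.19 log units; within the scatter). For compound 4 the estimated value is 4 mL.min-1.g-1, with an expected range of 1.2 mL.min-1.g-1 to 12 mL.min-1.g-1.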

Compound 4, intrinsic clearance in microsomes: 6.4 mL.min-1.g-1
Compound 4: middle estimate off by 1.6-fold (0.20 log units), on the low side; the measured number falls inside the stated range.
By their numbers in this assay, from the lowest: compounds 1 and 2 (each within the scatter of the next); then compound 3; then compound 4.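

In this assay, within the data shown here, the group on a saturated chain carbon bound to an aromatic nitrogen now spans a wider range than the earlier compounds showed, and 4-(methylsulfanyl)phenyl in place of 5-methyl-1,2-oxazol-3-yl gives a 2.5-fold higher number from compound 3 to compound 4 (0.39 log units; beyond the scatter) as the first direction for this change. Replacing the two groups at the low end gives larger steps: a 9.1-fold higher number from compound 2 to compound 4 (0.96 log units; beyond the scatter) for 1-acetylpiperidin-4-yl and a 9.1-fold higher number from compound 1 to compound 4 (0.96 log units; beyond the scatter) for pyridin-4-yl . Compound 4 therefore has the highest number of the four, beyond the scatter of every other compound, while compound 1 shows that an aromatic ring at this place does not by itself give a high number.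

Nothing available explains these differences. From the compounds shown here alone, whether a plain phenyl, or a methoxy or an amine in place of the methylsulfanyl group, would give a similar number remains open.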